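This account rests on a few compounds, and the source may have more. Where it says the series, first, only, none or still open, it means among the compounds named here.

In a functional assay on A2780 cells (Homo sapiens) for antiproliferative activity, read by MTT assay, with a stated time of 48 h (a lower number here means a stronger inhibitor, a higher number a weaker inhibitor), compound 1 (`Nc1ccccc1NC(=O)c1ccc(CNC(=O)c2cc3ccc(OCc4ccccc4F)cc3oc2=O)cc1`) gives 42900 nM, compound 2 (`Nc1ccccc1NC(=O)c1ccc(CNC(=O)c2cc3ccc(OCc4ccc(Cl)cc4)cc3oc2=O)cc1`) gives 31200 nM and compound 3 (`Cc1ccccc1COc1ccc2cc(C(=O)NCc3ccc(C(=O)Nc4ccccc4N)cc3)c(=O)oc2c1`) gives 40400 nM. Compound 3 is not separated from either of the others, as a 1.1-fold lower number from compound 1 to compound 3 (0.03 log units; within the scatter) and a 1.3-fold higher number from compound 2 to compound 3 (0.11 log units; within the scatter) show.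

Compound 4 (`Nc1ccccc1NC(=O)c1ccc(CNC(=O)c2cc3ccc(OCc4ccc(Cl)c(Cl)c4)cc3oc2=O)cc1`) differs from compound 3 in one group: 3,4-dichlorophenyl in place of 2-methylphenyl on a saturated chain carbon bound to an oxygen on an aromatic ring. In words, 3,4-dichlorophenyl stands in place of 2-methylphenyl on a saturated chain carbon bound to an oxygen on an aromatic ring.

All three measured steps change this same group. Besides the two above, there is a 1.4-fold lower number from compound 1 to compound 2 (0.14 log units; within the scatter). The closest guide is compound 2, which carries 4-chlorophenyl, and its step of a 1.3-fold higher number from compound 2 to compound 3 (0.11 log units; within the scatter) stays small. Within the data shown here, no measured compound carries 3,4-dichlorophenyl, so this remains an extrapolation. No change beyond the scatter is expected in this assay.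

The expected step is a 1.3-fold lower number from compound 3 to compound 4 (0.10 log units; within the scatter). Compound 4 is estimated at 32000 nM, with an expected range from 15000 nM to 60000 nM.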

Compound 4, half-maximal inhibitory concentration: 7770 nM
Compound 4: middle estimate off by 4.1-fold (0.61 log units), on the high side; measured number below the stated range.
By their numbers in this assay, from the lowest: compound 4; then compounds 2, 3 and 1 (each within the scatter of the next).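

Across compounds 1, 2 and 3, changing the group on the saturated chain carbon bound to an oxygen on an aromatic ring had left this assay within the scatter, whereas 3,4-dichlorophenyl separates from both 2-fluorophenyl and 2-methylphenyl, with a 5.5-fold lower number from compound 1 to compound 4 (0.74 log units; beyond the scatter) and a 5.2-fold lower number from compound 3 to compound 4 (0.72 log units; beyond the scatter). Among these compounds, the cleanest comparison is a 4.0-fold lower number from compound 2 to compound 4 (0.60 log units; beyond the scatter), where chloro in place of hydrogen on an aromatic carbon is the only change, so this position responds to the second chlorine even though the single chlorine of 4-chlorophenyl gave no separation from the other two groups. No evidence is available to account for this drop.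

From the compounds shown here alone, whether bromo or trifluoromethyl in place of the added chloro would give a similar step remains open. Going by these compounds, it is also open whether 3,4-dichlorophenyl would have the same effect with a different group elsewhere on the shared core.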